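From phenyl to 3,4-difluorophenyl in compound 2

The compounds below may be only part of what the source reports. "The series", "measured", "known", "first", "only" and "open" are said of these compounds alone.

Measured in a functional assay on HT-29 cells (Homo sapiens) for inhibition, read by MTT assay, with a stated time of 72 h; on this read-out lower numbers stand for stronger inhibition and higher numbers for weaker inhibition:
Compound 1 `COc1cc(NC(=O)/C=C/c2cccc(OCc3ccccc3)c2)cc(OC)c1OC`: 3600 nM
Compound 2 `C=C(Br)C(=O)Nc1cccc(/C=C/C(=O)Nc2ccccc2)c1`: 16600 nM

Compound 2 has the higher of the two numbers in this assay and is therefore the weaker inhibitor, and its gap to compound 1 lies beyond the usual scatter. The two compounds do not differ in just one place, so this gap does not show what any single change does.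

Compound 3 `C=C(Br)C(=O)Nc1cccc(/C=C/C(=O)Nc2ccc(F)c(F)c2)c1` has not yet been measured. It carries 3,4-difluorophenyl in place of phenyl on an amide-type nitrogen of compound 2. Going by the values given here, no measured pair shows what such a change does, so the expectation is loose. A modest move to a lower number in this assay is expected, and a result within the scatter would fit as well. The estimated step is a 1.8-fold lower number from compound 2 to compound 3 (0.27 log units; within the scatter) in size. For compound 3 the expected value is an estimated 9000 nM (range 3000 nM to 25000 nM).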

Compound 3, half-maximal inhibitory concentration: 8700 nM
Beside the measured number, compound 3's estimate is 1.0-fold (0.01 log units) above it; low and high end bracket the measured number.
By their numbers in this assay, from the lowest: compound 1; then compounds 3 and 2 (each within the scatter of the next).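

In this assay, placing 3,4-difluorophenyl in place of phenyl on an amide-type nitrogen gives a 1.9-fold lower number from compound 2 to compound 3 (0.28 log units; within the scatter), and this is the first pair shown that differs in one place. The step lies within the scatter, so this read-out does not separate the two groups at this position, and compound 3 and compound 2 stand on a level. Nothing available explains this result.

The compounds shown leave open whether another group on this nitrogen, such as an amine-bearing phenyl, a carboxylic acid-bearing phenyl or a longer chain, would give a step beyond the scatter. They also leave open which structural difference accounts for the gap between compound 1 and the other two, as compound 1 differs from them in more than one place.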